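The source may report more compounds than this note shows. Statements on the series, on what has been measured and on what is new or still open speak of the compounds shown alone.

Series notes, permeability track.

Going by the values given here, compound 1 `COc1ccc(F)cc1CNCCCNc1ccnc2cc(Cc3ccc(C#N)cc3)ccc12` and compound 2 `COc1cccc(CNCCCNc2ccnc3cc(-c4ccc(F)cc4)ccc23)c1O` are the two compounds with numbers so far. In an ADME assay for permeability, using PAMPA, with a stated time of 30 min, at pH 7.4 (a lower number here means that the compound crosses the layer more slowly, a higher number that the compound crosses the layer faster), compound 1 gives 23 10^-6 cm/s, and in this assay compound 2 gives 237 10^-6 cm/s. Compound 1 therefore stands at the lower of the two numbers; the gap to compound 2 lies beyond the scatter, but the two differ in several places at once, so the pair says nothing about any single change.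

Compound 3 `COc1ccc(Oc2ccc3c(NCCCNCc4cc(F)ccc4OC)ccnc3c2)cc1` is the next compound to be run in this assay. It differs from compound 1 in one place: 4-methoxyphenoxy in place of 4-cyanobenzyl on an aromatic carbon. Among the compounds with values here, no measured pair covers this exchange, so there is nothing to read the step from. The shared core, the chain and the benzylamine end carry over unchanged from compound 1.

The working expectation for compound 3 is a step upward from compound 1 in this assay, of a size that could just exceed the scatter but stays well short of the gap between compound 1 and compound 2. The estimated step is a 2.4-fold higher number from compound 1 to compound 3 (0.38 log units; beyond the scatter). Compound 3 is accordingly expected to give 55 10^-6 cm/s in this assay, within a range of 18 10^-6 cm/s to 170 10^-6 cm/s.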

Compound 3, apparent permeability: 317 10^-6 cm/s
Compound 3: the middle estimate sits 5.8-fold (0.76 log units) below what was measured; the whole stated range lies below it.
By their numbers in this assay, from the lowest: compound 1; then compounds 2 and 3 (each within the scatter of the next).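

In this assay, going by these compounds alone, 4-methoxyphenoxy in place of 4-cyanobenzyl on an aromatic carbon gives a 14-fold higher number from compound 1 to compound 3 (1.14 log units; beyond the scatter), the first step that can be read at a single place, with the shared core, the chain and the benzylamine end unchanged. This position can therefore move the number by a large margin, and it does so between two groups that both count 9 heavy atoms and one six-membered aromatic ring of carbon only, while the exchange removes the triple bond and changes the hydrogen-bond acceptor count from 1 to 2. Within the data shown here, nothing measured so far ties the step to any one of these differences.

The compounds shown leave open whether the step follows the oxygen attached to the aromatic carbon, the methoxy group or the loss of the nitrile; a 4-cyanophenoxy or a 4-methoxybenzyl group at this place would separate these. Also open, as far as these compounds go, is how the same aromatic carbon behaves with a quite different substituent, such as an amine or a carboxylic acid, and whether the step holds with a longer chain.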